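Fluoro for methyl on the benzyl arm of compound 2

The source may hold more compounds than are shown below. What is called first, only, known or untested is meant among the compounds shown, and "the series" means these compounds.

Measured compounds:
Compound 1, `CCCCc1cnc(CCc2ccc(-c3ccccc3C(=O)O)cc2)[nH]1`, 2710 nM
Compound 2, `Cc1ccc(Cc2cnc(CCc3ccc(-c4ccccc4C(=O)O)cc3)[nH]2)cc1`, 2660 nM

Of the compounds shown here, two have been tested in an in vitro functional assay on cells for agonist activity at Bombesin receptor subtype-3 (Homo sapiens), read by luminescence and calcium flux; a lower number here means that less compound is needed, a higher number that more compound is needed for the effect. Compound 1 gives 2710 nM, and compound 2 gives 2660 nM; the two numbers sit together within the scatter, so neither is called stronger than the other. Within the data shown here, the only measured step, a 1.0-fold lower number from compound 1 to compound 2 (0.01 log units; within the scatter), shows that replacing propyl by 4-methylphenyl on the saturated chain carbon bound to an aromatic carbon left the number essentially unchanged.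

Compound 3, `O=C(O)c1ccccc1-c1ccc(CCc2ncc(Cc3ccc(F)cc3)[nH]2)cc1`, is not yet measured. It differs from compound 2 in one place: fluoro in place of methyl on an aromatic carbon. Among the measured compounds shown here, no measured step touches this position; the earlier step concerns the group on the saturated chain carbon, not a substituent on the aromatic carbon para to a large group, so it bears only indirectly, by showing that this arm of the molecule has so far tolerated change without moving the number. On that basis compound 3 is expected to stay close to compound 2, with an estimated step of a 1.0-fold higher number from compound 2 to compound 3 (0.01 log units; within the scatter), not beyond the scatter. The estimate for compound 3 in this assay is 2700 nM, within a range of 1200 nM to 6000 nM.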

Compound 3, half-maximal effective concentration: 1600 nM
Compound 3: the middle estimate sits 1.7-fold (0.23 log units) above what was measured, within the range that was stated.
By their numbers in this assay, from the lowest: compounds 3, 2 and 1 (each within the scatter of the next).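

In this assay, among these compounds, the exchange of methyl for fluoro on an aromatic carbon para to a large group gives a 1.7-fold lower number from compound 2 to compound 3 (0.22 log units; within the scatter) and so stays inside the scatter, which shows for the first time that this substituent on the ring of the benzyl arm can change without a clear shift in the number. Set against the propyl-bearing compound, the 4-fluorophenyl group gives a 1.7-fold lower number from compound 1 to compound 3 (0.23 log units; within the scatter) and is likewise inside the scatter, so the three compounds still cannot be separated and neither the arm nor this substituent has yet been shown to matter for the number. No measurement is available that would account for these small differences.

What the compounds leave open is whether a larger or differently built group on this aromatic carbon, such as methoxy, trifluoromethyl or an amine, would move the number beyond the scatter. Also open, from the compounds shown here alone, is how the number responds to changes elsewhere on the shared core, for instance an amide or a tetrazole in place of the carboxylic acid, or a longer chain in place of the two-carbon link.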